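Swapping Methoxy for Nitro: From Compound 1 to Compound 4

The compounds below may be only part of what the source reports. "The series", "measured", "known", "first", "only" and "open" are said of these compounds alone.

Compound 1 `COc1ccc2c(c1)C(=O)C(=O)N2CCCCCn1cc(COc2cc(=O)oc3ccccc23)nn1`: 19%
Compound 2 `O=C1C(=O)N(CCCCn2cc(COc3cc(=O)oc4ccccc34)nn2)c2ccc(Cl)cc21`: 60%
Compound 3 `COc1ccc2c(c1)C(=O)C(=O)N2CCCn1cc(COc2cc(=O)oc3ccccc23)nn1`: 48%

All three were tested in a functional assay on COLO 205 cells (Homo sapiens) for inhibition, read by sulforhodamine B assay, with a stated time of 48 h, tested at 50 uM; a lower number here means less inhibition of growth, a higher number more inhibition of growth at the concentration tested. Compound 1 gives the lowest of the three numbers; compound 3 lies higher by a margin beyond the usual scatter, and compound 2 higher still, also beyond the scatter. Compound 4 `O=C1C(=O)N(CCCCCn2cc(COc3cc(=O)oc4ccccc34)nn2)c2ccc([N+](=O)[O-])cc21` has not yet been measured. It differs from compound 1 in one place: nitro in place of methoxy on an aromatic carbon. Among the measured compounds shown here, no measured pair differs in exactly this way, so the size of the step is uncertain. Since compound 2, which also lacks the methoxy, gives 60% in this assay, a gain seems plausible. The step of a number 21 percentage points higher from compound 1 to compound 4 (beyond the scatter) is expected to be an increase beyond the scatter. Compound 4 is estimated at 40%, ranging from 15% to 65%.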

Compound 4, percent growth inhibition at one concentration: 23%
For compound 4 the middle estimate is 17 percentage points above the measured one, within the range that was stated.
By their numbers in this assay, from the lowest: compounds 1 and 4 (each within the scatter of the next); then compound 3; then compound 2.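

In this assay, among the compounds shown here, placing nitro instead of methoxy on this aromatic carbon gives a number 4 percentage points higher from compound 1 to compound 4 (within the scatter), the first direct reading of this change. With the rest of compound 1 kept, the two groups therefore cannot be told apart in this growth test at this position. Nothing measured here explains this result.

As far as these compounds go, it remains open whether an amine or a carboxylic acid on the same carbon would give a clearly different number. From the compounds shown here alone, whether the swap would behave the same way on a shorter chain also remains open.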